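The source may hold more compounds than are shown below. What is called first, only, known or untested is meant among the compounds shown, and "the series" means these compounds.

Measured so far:
compound 1 `COc1cc2c(cc1O)O[C@H](c1ccccc1)[C@@H](O)C2=O`: > 100000 nM
compound 2 `COc1ccc(-c2coc3cc(O)ccc3c2=O)c(O)c1`: > 100000 nM
compound 3 `COc1ccc(-c2coc3cc(O)cc(O)c3c2=O)cc1O`: > 100000 nM

In a functional assay on Lewis lung carcinoma cells (Mus musculus) for cytotoxicity, read by MTT assay, with a stated time of 72 h (a higher number here means a weaker inhibitor, a lower number a stronger inhibitor), compound 1 reaches only the assay limit, > 100000 nM. Compound 2 likewise returns only a limit, > 100000 nM. Compound 3 also returns only a limit, > 100000 nM. Among the measured compounds shown here, compound 2 therefore stands nowhere apart from the rest of the set: every value shown is the limit of > 100000 nM in this assay, at which 3 of the 3 values shown sit, and no step between measured compounds can be computed, since none of the three has a number to compare.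

Compound 4 `COc1ccc(-c2coc3cc(O)cc(O)c3c2=O)c(O)c1` is the next compound to be tested in this assay. It differs from compound 2 by hydroxy in place of hydrogen on an aromatic carbon. With compound 2 and compound 3 both sitting at the limit, and compound 3 already carrying two hydroxy groups on the fused ring, the data give no basis for expecting the added hydroxy group to pull compound 4 into the measurable range. The expected step is a number no higher from compound 2 to compound 4 (the limit leaves the size open), that is, nothing beyond the scatter. Compound 4 is expected to come out at about 100000 nM, in the range 40000 nM to 300000 nM, most likely again as a limit rather than a number.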

Compound 4, half-maximal inhibitory concentration: > 100000 nM
Compound 4 gave a limit, no number; the forecaster's own chance of this, stated with the estimate: 85%; the middle value lies on the limit itself.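

Compound 2 and compound 4 both return only a limit, so no step can be read between them: the limit of > 100000 nM in this assay, at which 4 of the 4 values shown sit.

The compounds shown leave open what a hydroxy group contributes on the shared core, and which change, if any, would give a number rather than a limit.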